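Acyloxymethyl ester variation and blood half-life

The source may hold more compounds than are shown below. What is called first, only, known or untested is meant among the compounds shown, and "the series" means these compounds.

Compound 3 `COC(=O)CCNC(=O)[C@@H]1O[P@](=O)(OCOC(=O)c2ccns2)OCC1(C)C` in an ADME assay on blood (Homo sapiens) for pharmacokinetics (a higher number here means that the compound lasts longer, a lower number that the compound disappears faster), gives < 0.16 h, which is a limit of the assay rather than a number. Compound 1 `COC(=O)CCNC(=O)[C@@H]1O[P@](=O)(OCOC(=O)c2ccnn2C)OCC1(C)C` in this assay likewise gives < 0.16 h, again a limit. Among the measured compounds shown here, compound 2 `COC(=O)CCNC(=O)[C@@H]1O[P@](=O)(OCOC(=O)c2scnc2C(C)(C)C)OCC1(C)C` in this assay gives 0.44 h, the only true number in the set, and the other two sit at the limit of < 0.16 h in this assay, at which 2 of the 3 values shown sit. The change to compound 4 `COC(=O)CCNC(=O)[C@@H]1O[P@](=O)(OCOC(=O)c2cc(C(C)(C)C)n[nH]2)OCC1(C)C` is 3-(tert-butyl)-1H-pyrazol-5-yl in place of 1,2-thiazol-5-yl on a carbonyl carbon. For the measured compounds named here, two measured steps bear on it: an at least 2.7-fold higher number from compound 1 to compound 2 (0.43 log units; beyond the scatter) and an at least 2.7-fold lower number from compound 2 to compound 3 (0.43 log units; beyond the scatter). In both, the compound whose five-membered ring carries a tert-butyl group returns the higher number, and compound 4 again carries a tert-butyl group on its five-membered ring, so a rise beyond the scatter is expected in this assay. Because compound 2 gives 0.44 h with such a group, compound 4 is expected to reach about 0.35 h, with a range from 0.15 h to 0.8 h. The step of an at least 2.1-fold higher number from compound 3 to compound 4 (0.33 log units; beyond the scatter) is the expected size, with a real chance that only the limit is reported again.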

Compound 4, half-life: < 0.16 h
Compound 4 gave a limit, no number (the forecaster's own chance of this, stated with the estimate: 25%); at least 2.1-fold (0.33 log units) between middle value and limit.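

Carrying a tert-butyl group on the five-membered ring does not by itself hold up the number in this assay: 3-(tert-butyl)-1H-pyrazol-5-yl in place of 4-(tert-butyl)-1,3-thiazol-5-yl on the carbonyl carbon gives an at least 2.7-fold lower number from compound 2 to compound 4 (0.43 log units; beyond the scatter). Among the compounds shown here, compound 4 therefore goes against the link between tert-butyl and a higher number seen in the earlier compounds, and compound 2 remains the only one with a true number, the rest resting at a limit: the limit of < 0.16 h in this assay, at which 3 of the 4 values shown sit. The steps from compound 3 to compound 4 and from compound 1 to compound 4 cannot be read, since both ends are limits.

The shown compounds do not separate the role of the ring itself from that of where the tert-butyl group sits on it. On these data alone, whether an isopropyl or cyclopropyl group on the 1,3-thiazol-5-yl ring would also give a true number remains open.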